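Swapping chlorines for methyls on the aryl piperazine

The compounds below may be only part of what the source reports. "The series", "measured", "known", "first", "only" and "open" are said of these compounds alone.

Of the compounds shown here, two that share one core have been measured so far. Compound 1 `CC1(c2ccc(F)cc2)NC(=O)N(CC(O)CN2CCN(c3ccccc3C#N)CC2)C1=O` gives 14 nM in an assay on HEK293 cells for displacement of a labelled ligand from 5-hydroxytryptamine receptor 7 (Homo sapiens); on this read-out higher numbers stand for weaker inhibition and lower numbers for stronger inhibition. Within the data shown here, compound 2 `CC1(c2ccc(F)cc2)NC(=O)N(CC(O)CN2CCN(c3ccc(Cl)c(Cl)c3)CC2)C1=O` gives 141 nM in this assay; among the two numbers it stands highest, and the only step measured between them is a 10-fold higher number from compound 1 to compound 2 (1.00 log units; beyond the scatter). The new compound 3 `Cc1ccc(N2CCN(CC(O)CN3C(=O)NC(C)(c4ccc(F)cc4)C3=O)CC2)cc1C` differs from compound 2 by 3,4-dimethylphenyl in place of 3,4-dichlorophenyl on an amine nitrogen in a ring. Among the measured compounds shown here, no measured step pairs two groups that both carry substituents at these same positions of the phenyl ring; the single measured step exchanges a 2-cyanophenyl for a 3,4-dichlorophenyl, so it speaks to a different kind of change. For the measured compounds named here, with only that to go on, the change from two chlorines to two methyls is expected to leave the number close to where compound 2 sits, with no step expected beyond the scatter: a 1.2-fold lower number from compound 2 to compound 3 (0.07 log units; within the scatter). Compound 3 is therefore estimated at 120 nM, with a likely range from 40 nM to 400 nM.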

Compound 3, inhibition constant: 177 nM
Beside the measured number, compound 3's estimate is 1.5-fold (0.17 log units) below it, and the stated range covers the measured number.
By their numbers in this assay, from the lowest: compound 1; then compounds 2 and 3 (each within the scatter of the next).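

In this assay, putting two methyls where the two chlorines stood gives a 1.3-fold higher number from compound 2 to compound 3 (0.10 log units; within the scatter), so on this ring nitrogen the measurement does not separate these two groups. The other new step, a 13-fold higher number from compound 1 to compound 3 (1.10 log units; beyond the scatter), shows that compound 1 keeps its clear lead over 3,4-dimethylphenyl as well as over 3,4-dichlorophenyl, so the lead does not depend on one particular pair of substituents among these three compounds. Nothing available explains why the two groups read alike or why compound 1 stands apart.

The compounds shown leave open whether the lower number of compound 1 belongs to the nitrile itself or to where it sits on the phenyl ring, since its steps change both at once. As far as these compounds go, how a methoxy group or a plain unsubstituted phenyl would read on this nitrogen also remains unknown.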